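The compounds below may be only part of what the source reports. "The series", "measured", "known", "first", "only" and "open" are said of these compounds alone.

Two compounds have been measured so far in a functional assay on CHO cells for activation of 5-hydroxytryptamine receptor 1D (Homo sapiens), read by GTPgammaS binding; on this read-out lower numbers stand for an effect already at smaller amounts and higher numbers for an effect only at larger amounts of compound:

compound 1 `c1ccc(CN2CCN(CCCc3c[nH]c4ccc(-n5cnnc5)cc34)CC2)nc1` gives 0.3 nM
compound 2 `c1coc(CN2CCN(CCCc3c[nH]c4ccc(-n5cnnc5)cc34)CC2)c1` gives 0.5 nM

On these two numbers compound 2 holds the higher one, and its nearest neighbour is compound 1; the step between them, a 1.7-fold higher number from compound 1 to compound 2 (0.22 log units; within the scatter), lies within the scatter, so the two compounds cannot be told apart on this read-out. Compound 3 `c1c[nH]c(CN2CCN(CCCc3c[nH]c4ccc(-n5cnnc5)cc34)CC2)n1` is the next compound and has not yet been measured. It differs from compound 2 in a single place: 1H-imidazol-2-yl in place of furan-2-yl on a saturated chain carbon bound to an amine nitrogen in a ring.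

Only one measured step bears on this change, the exchange of one small aromatic ring for another at the same place on the chain carbon bound to the ring amine nitrogen, which is the step from compound 1 to compound 2 described above. That step stayed within the scatter. A further exchange of the same kind at the same place is therefore expected to leave the number in this assay essentially where it is, with no step beyond the scatter: the expected step is a 1.4-fold higher number from compound 2 to compound 3 (0.15 log units; within the scatter). On that basis compound 3 is estimated at 0.7 nM, with a range from 0.25 nM to 2.5 nM.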

Compound 3, half-maximal effective concentration: 2 nM
Beside the measured number, compound 3's estimate is 2.9-fold (0.46 log units) below it; the range from low to high includes it.
By their numbers in this assay, from the lowest: compounds 1 and 2 (each within the scatter of the next); then compound 3.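

In this assay, this position proves sensitive to which small aromatic ring it carries: the earlier ring exchange stayed within the scatter, whereas 1H-imidazol-2-yl in place of furan-2-yl gives a 4.0-fold higher number from compound 2 to compound 3 (0.60 log units; beyond the scatter), and in place of pyridin-2-yl it gives a 6.7-fold higher number from compound 1 to compound 3 (0.82 log units; beyond the scatter), both modest steps beyond the scatter. Compared with furan-2-yl, the entering ring has one more hetero atom and adds a hydrogen-bond donor, but these two differences arrive together in a single change, so this step cannot assign the shift to either one. Nothing among the available data explains why the number rises with this ring.

The compounds shown leave open what a 1-methyl-1H-imidazol-2-yl group would give, a ring that keeps both nitrogens but carries a methyl group in place of the hydrogen on nitrogen, and such a comparison could help separate the donor from the second hetero atom. Also open, as far as these compounds go, is how a plain phenyl ring or a saturated cyclohexyl group would compare at this same place.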